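The source may report more compounds than this note shows. Statements on the series, on what has been measured and on what is new or still open speak of the compounds shown alone.

Three compounds built on one shared core were examined in a functional assay on MCF7 cells (Homo sapiens) for cytotoxicity, read by MTT assay, with a stated time of 48 h; a higher number here means a weaker inhibitor, a lower number a stronger inhibitor. Compound 3, `CC(C)(c1nccs1)C(C#N)C#N`, gives only a limit of the assay, > 120000 nM. Compound 2, `CC(c1nccs1)C(C#N)C#N`, likewise gives a limit, > 120000 nM. Compound 1, `CC(c1nccs1)C(C#N)(C#N)CCC(F)=C(F)F`, also gives a limit, > 120000 nM. Since all three sit at the limit of > 120000 nM in this assay, at which 3 of the 3 values shown sit, no order among them can be read. The change from compound 3 to compound 2 is hydrogen in place of methyl on a saturated chain carbon bound to an aromatic carbon and two saturated chain carbons; the step that the two limits leave unreadable from compound 3 to compound 2 stays unreadable because the limit of > 120000 nM in this assay, at which 3 of the 3 values shown sit, covers both ends. The difference between the core of compound 1 and that of compound 3 is not broken down here.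

Compound 4, `N#CC(C#N)(CCC(F)=C(F)F)Cc1nccs1`, awaits measurement. It differs from compound 1 by hydrogen in place of methyl on a saturated chain carbon bound to an aromatic carbon and a saturated chain carbon, the same kind of change as from compound 3 to compound 2, though the carbon carrying it is bound to an aromatic carbon and a saturated chain carbon rather than to an aromatic carbon and two saturated chain carbons. The step from compound 1 to compound 4 is expected to be a step that the limit leaves unreadable from compound 1 to compound 4, set beside a step that the two limits leave unreadable from compound 3 to compound 2, resting on compound 1 giving only the limit > 120000 nM. In this assay compound 4 is estimated at about 150000 nM, likely between 50000 nM and 600000 nM, most probably again as a limit.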

Compound 4, half-maximal inhibitory concentration: > 120000 nM
Compound 4: no number, only a limit (the forecaster's own chance of this, stated with the estimate: 85%); the middle value is on the limit's open side.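

In this assay compound 4 gives > 120000 nM, which is a limit of the assay and not a number. Compound 1 gives a limit too, so no new step can be read between compound 1 and compound 4: the limit of > 120000 nM in this assay, at which 4 of the 4 values shown sit. The compounds shown leave open which change to the shared core, if any, would give a readable value in this assay.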